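Swapping the aminophenyl for a dichlorophenyl on a chalcone-like core

The source may hold more compounds than are shown below. What is called first, only, known or untested is meant among the compounds shown, and "the series" means these compounds.

The account concerns two measured compounds and one still untested, all sharing a core in which a pyrazole-bearing enone carries an aryl ketone. Compound 1 `COc1cc(-c2cc(/C=C/C(=O)c3ccc(N)cc3)[nH]n2)cc(OC)c1OC` has a 4-aminophenyl on its carbonyl carbon, and compound 2 `COc1ccc(-c2cc(/C=C/C(=O)c3ccc(OC)c(OC)c3)[nH]n2)cc1` a dimethoxyphenyl there. In a functional assay on NCI-H322M cells (Homo sapiens) for inhibition, read by sulforhodamine B assay, with a stated time of 48 h (a lower number here means a stronger inhibitor of growth, a higher number a weaker inhibitor of growth), compound 1 gives 2230 nM, and compound 2 gives 1620 nM; the gap between the two lies within the usual scatter, so neither stands apart from the other.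

Compound 3 `COc1cc(-c2cc(/C=C/C(=O)c3ccc(Cl)c(Cl)c3)[nH]n2)cc(OC)c1OC` differs from compound 1 in one place: 3,4-dichlorophenyl in place of 4-aminophenyl on a carbonyl carbon. No comparable step between measured compounds is available, so the direction and size of the change rest on nothing more than the two numbers shown. The author expects the step of a 1.5-fold lower number from compound 1 to compound 3 (0.17 log units; within the scatter) to be small and not clearly beyond the scatter. Compound 3 is therefore estimated at 1500 nM, with a range from 500 nM to 5000 nM.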

Compound 3, concentration for 50% growth inhibition: 14500 nM
Beside the measured number, compound 3's estimate is 9.7-fold (0.99 log units) below it; the whole stated range lies below it.
By their numbers in this assay, from the lowest: compounds 2 and 1 (each within the scatter of the next); then compound 3.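

Compounds 1 and 2 differ in more than one place, so their values could not isolate the group on the carbonyl carbon. Within the data shown here, the single change from 4-aminophenyl to 3,4-dichlorophenyl does isolate it, and in this assay it gives a 6.5-fold higher number from compound 1 to compound 3 (0.81 log units; beyond the scatter) with the step lying beyond the scatter, so this position is not indifferent to the aryl group it carries. No measurement offered here accounts for the step.

The compounds shown leave open whether the weaker inhibition of growth follows from the loss of the 4-aminophenyl or from the arrival of the 3,4-dichlorophenyl, a question that a plain phenyl or a phenyl carrying a single chlorine on the carbonyl carbon would address. They also leave open whether the same swap has a similar effect on the core of compound 2.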